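Replacing the Amide at the Benzylic Ring of Compound 3

The compounds below may be only part of what the source reports. "The series", "measured", "known", "first", "only" and "open" are said of these compounds alone.

Measured compounds:
- compound 1, `O=C(O)CNc1cccc(CNc2cc(C(F)(F)F)cc3[nH]ncc23)c1`: > 100000 nM
- compound 2, `O=C(O)c1cccc(CNc2cc(C(F)(F)F)cc3[nH]ncc23)c1`: 1690 nM
- compound 3, `CNC(=O)c1cccc(CNc2cc(C(F)(F)F)cc3[nH]ncc23)c1`: 4870 nM

In an assay for inhibition of Tryptophan 2,3-dioxygenase (Homo sapiens), with stated times of 10 min and 60 min (a higher number here means a weaker inhibitor, a lower number a stronger inhibitor), compound 1 gives only a limit, > 100000 nM, not a number. Compound 2 gives 1690 nM, the lowest number of the set. Compound 3 gives 4870 nM and stands highest of the two numbers; its nearest neighbour is compound 2, the step being a 2.9-fold higher number from compound 2 to compound 3 (0.46 log units; beyond the scatter). The two changes from compound 1 are both large: an at least 59-fold lower number from compound 1 to compound 2 (1.77 log units; beyond the scatter) and an at least 20-fold lower number from compound 1 to compound 3 (1.31 log units; beyond the scatter), though each is bounded by the limit of compound 1 (the limit of > 100000 nM in this assay, at which 1 of the 3 values shown sits).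

Compound 4, `FC(F)(F)c1cccc(CNc2cc(C(F)(F)F)cc3[nH]ncc23)c1`, has not yet been measured. Its change from compound 3 is trifluoromethyl in place of methylcarbamoyl on an aromatic carbon. For the measured compounds named here, none of the measured steps exchanges a methylcarbamoyl for a trifluoromethyl, so the bearing is indirect. The steps measured so far show that the group on this ring carbon moves the number over a wide span, from the limit of compound 1 down to compound 2, and that removing the hydroxy of compound 2 for methylamino already raised it, a 2.9-fold higher number from compound 2 to compound 3 (0.46 log units; beyond the scatter). Trifluoromethyl keeps neither donor nor acceptor, so for compound 4 a further upward step of modest size is expected, a 2.5-fold higher number from compound 3 to compound 4 (0.39 log units; beyond the scatter), with a real chance that only a limit results. Compound 4 is therefore estimated at 12000 nM, within 2500 nM to 60000 nM.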

Compound 4, half-maximal inhibitory concentration: 12200 nM
For compound 4 the middle estimate is 1.0-fold (0.01 log units) below the measured one; the measured number falls inside the stated range.
By their numbers in this assay, from the lowest: compound 2; then compound 3; then compound 4. At a limit, above all of these: compound 1.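

Exchanging methylcarbamoyl for trifluoromethyl removes the hydrogen-bond donor and acceptor counted for the leaving group at an equal count of heavy atoms, yet in this assay this costs only a modest step, a 2.5-fold higher number from compound 3 to compound 4 (0.40 log units; beyond the scatter), so a measurable number survives without either. Set against the carboxy group, the same position shows a larger change, a 7.2-fold higher number from compound 2 to compound 4 (0.86 log units; beyond the scatter), and the three groups now run in the order carboxy, methylcarbamoyl, trifluoromethyl from lowest number to highest, each step beyond the scatter. Even trifluoromethyl stands clear of (carboxymethyl)amino, an at least 8.1-fold lower number from compound 1 to compound 4 (0.91 log units; beyond the scatter), a step bounded on one side only, as compound 1 gives a limit and not a number: the limit of > 100000 nM in this assay, at which 1 of the 4 values shown sits.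

Open, on these data alone, is whether a methyl ester, a primary amide or a nitrile on this ring carbon would fall nearer to compound 2 or to compound 4. Also open, as far as these compounds go, is whether the result for compound 1 belongs to its amine nitrogen or to its longer chain, which a plain amine or an acetic acid side chain joined through carbon on the same ring carbon would separate.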